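Swapping a methoxy for fluoro on a shared core

The compounds below may be only part of what the source reports. "The series", "measured", "known", "first", "only" and "open" are said of these compounds alone.

Among the measured compounds shown here, compound 1 `COc1ccc(-c2ccc(-c3ccc(C(=N)N)cc3)s2)cc1` gives 211 nM in a functional assay on SW-620 cells (Homo sapiens) for inhibition, read by sulforhodamine B assay, with a stated time of 48 h (on this read-out lower numbers stand for stronger inhibition of growth and higher numbers for weaker inhibition of growth), the lower of the two numbers measured so far. Compound 2 `N=C(N)c1ccc(-c2ccc(-c3cc(Cl)cc(Cl)c3)s2)cc1` gives 318 nM in this assay, and the two values sit within the usual scatter of each other, so neither can be called stronger. Compound 3 `N=C(N)c1ccc(-c2ccc(-c3ccc(F)cc3)s2)cc1` has not yet been measured. It differs from compound 1 in one place: fluoro in place of methoxy on an aromatic carbon. For the measured compounds named here, no measured step of this kind exists here to lean on, so only a modest shift, if any, is expected. Compound 3 is therefore estimated at about 300 nM, within 120 nM to 750 nM. This expected step, a 1.4-fold higher number from compound 1 to compound 3 (0.15 log units; within the scatter), stays close to the usual scatter.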

Compound 3, concentration for 50% growth inhibition: 386 nM
Beside the measured number, compound 3's estimate is 1.3-fold (0.11 log units) below it; the measured number falls inside the stated range.
By their numbers in this assay, from the lowest: compounds 1, 2 and 3 (each within the scatter of the next).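

Replacing methoxy with fluoro on an aromatic carbon, para to a large group, gives in this assay a 1.8-fold higher number from compound 1 to compound 3 (0.26 log units; within the scatter). Among the compounds shown here, this is the first single-place step at this position, and it shows that exchanging these two groups, though they differ in heavy atoms and hydrogen-bond acceptors, produces no change distinguishable from the scatter. No available measurement offers an explanation for this result. On these data alone, whether an amine or a carboxylic acid at this position would move the number beyond the scatter remains open, as does whether the same exchange behaves alike on another core.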